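This account rests on a few compounds, and the source may have more. Where it says the series, first, only, none or still open, it means among the compounds named here.

Compound 2 `CCOC(=O)C1=C(C)NC(C)=C(C(=O)OCC)C1c1c(-c2cc([N+](=O)[O-])c(Cl)cc2Cl)nc2sc(Cl)cn12` gives 81 nM in an ADME assay on Left cardiac atrium (Cavia porcellus) (a lower number here means that less compound is needed, a higher number that more compound is needed for the effect), the lowest of the two numbers measured; the nearest is compound 1 `CCOC(=O)C1=C(C)NC(C)=C(C(=O)OCC)C1c1c(-c2ccc([N+](=O)[O-])cc2)nc2sc(Cl)cn12`, which in this assay gives 1370 nM. Within the data shown here, the single measured step, a 17-fold lower number from compound 1 to compound 2 (1.23 log units; beyond the scatter), concerns the nitrophenyl group and not the place changed here. Compound 3 `CCOC(=O)C1=C(C)NC(C)=C(C(=O)OCC)C1c1c(-c2cc([N+](=O)[O-])c(Cl)cc2Cl)nc2sc(CC)cn12` differs from compound 2 by ethyl in place of chloro on an aromatic carbon, next to the ring sulfur. Among the measured compounds shown here, no measured step touches that position, so the direction is open and a change within the scatter is expected, no change at the digits printed from compound 2 to compound 3 (within the scatter). Compound 3 is therefore estimated at 81 nM, with a range from 20 nM to 320 nM.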

Compound 3, half-maximal effective concentration: 33 nM
Compound 3: middle estimate off by 2.5-fold (0.39 log units), on the high side; the range from low to high includes it.
By their numbers in this assay, from the lowest: compound 3; then compound 2; then compound 1.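

In this assay, ethyl in place of chloro on this carbon next to the ring sulfur gives a 2.5-fold lower number from compound 2 to compound 3 (0.39 log units; beyond the scatter), a modest step beyond the scatter. The position, which the earlier step did not touch, therefore has a measurable bearing on the number, and chloro is not required there. No measurement available here explains this shift. The compounds shown leave open whether a longer chain such as propyl, or an amine, at this carbon would lower the number further or raise it, and whether the step would be the same with the 4-nitrophenyl group of compound 1.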